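The source may report more compounds than this note shows. Statements on the series, on what has been measured and on what is new or still open speak of the compounds shown alone.

Working notes on the series.

Of the compounds shown here, two have numbers so far. Compound 1, `CC(C)(C)c1ccc(OCCCON2C(N)=NC(N)=NC23CCSCC3)cc1`, gives 280 nM in a functional assay on HL-60 cells (Homo sapiens) for antiproliferative activity, read by MTT assay, with a stated time of 72 h; on this read-out lower numbers stand for stronger inhibition and higher numbers for weaker inhibition. Compound 2, `NC1=NC2(CCOCC2)N(OCCCOc2cccc(Cl)c2Cl)C(N)=N1`, gives 440 nM in this assay; of the two numbers it is the one that stands higher, yet the distance to compound 1 is within the scatter of this kind of measurement, so the two compounds cannot be told apart on this read-out. The two also differ in more than one place, so no single change can be tied to the small gap between them.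

The next compound, compound 3, `NC1=NC2(CCOCC2)N(OCCCOc2cccc(Cl)c2)C(N)=N1`, shares the core of compound 2 and departs from it at a single point: hydrogen in place of chloro on an aromatic carbon. The remaining chloro group and the long chain linking the aryl ring to the core are kept.

Among the measured compounds shown here, no pair that differs in one place has yet been measured here, so there is no step to lean on. The expectation is that the step from compound 2 to compound 3 in this assay will be small, leaning towards weaker inhibition, and may not clear the scatter; the estimated step is a 1.4-fold higher number from compound 2 to compound 3 (0.13 log units; within the scatter). Compound 3 is accordingly expected to give about 600 nM, with a range from 250 nM to 1500 nM.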

Compound 3, half-maximal inhibitory concentration: 520 nM
Compound 3: middle estimate off by 1.2-fold (0.06 log units), on the high side, within the range that was stated.
By their numbers in this assay, from the lowest: compounds 1, 2 and 3 (each within the scatter of the next).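

This pair gives the series its first step in a single place: with hydrogen in place of chloro on the aromatic carbon ortho to the remaining chloro group, the change from 2,3-dichlorophenyl to 3-chlorophenyl gives a 1.2-fold higher number from compound 2 to compound 3 (0.07 log units; within the scatter) in this assay and leaves the two compounds indistinguishable on this read-out. With the shared core and the long chain held constant, this chloro group is therefore not shown to be needed to keep the number in the range seen for compound 2, and this one change gives no sign that the position is sensitive. No measurement available here bears on the reason for this result.

Open, on these data alone, is whether a different group on this aromatic carbon, such as an amine, a methoxy group or a carboxylic acid, would give a step that clears the scatter, or whether the position tolerates these as well. Equally open, as far as these compounds go, is whether hydrogen in place of chloro would stay this small a step with a shorter or longer chain linking the aryl ring to the core.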